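The source may report more compounds than this note shows. Statements on the series, on what has been measured and on what is new or still open speak of the compounds shown alone.

Three compounds share one core and differ only in the group carried on the outer six-membered aromatic ring of carbon only. Compound 1 `CCN(CC)c1ccc(-c2cccc(C#N)c2)nn1` and compound 2 `CCN(CC)c1ccc(-c2ccc(C#N)cc2)nn1` both carry a cyano group there, while compound 3 `CCOC(=O)c1ccc(-c2ccc(N(CC)CC)nn2)cc1` carries an ethoxycarbonyl group. They were tested in a functional assay on Caco-2 cells (Homo sapiens) for antiproliferative activity, with a stated time of 48 h; a higher number here means a weaker inhibitor, a lower number a stronger inhibitor. In this assay compound 1 gives only a limit, > 25000 nM, not a number. Compound 2 likewise reaches only a limit, > 25000 nM. Compound 3 gives 4000 nM. The change from compound 2 to compound 3 is ethoxycarbonyl in place of cyano on an aromatic carbon, and it produced an at least 6.2-fold lower number from compound 2 to compound 3 (0.79 log units; beyond the scatter). How the cores of compound 1 and compound 2 differ is not broken down here.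

Compound 4 `CCOC(=O)c1cccc(-c2ccc(N(CC)CC)nn2)c1` is not yet measured. It differs from compound 1 by ethoxycarbonyl in place of cyano on an aromatic carbon. This is the same kind of change as from compound 2 to compound 3, but the place is not the same: there the new group sat para to a large group, here it sits meta to a large group. Resting on the earlier step, compound 4 is expected to show an at least 3.5-fold lower number from compound 1 to compound 4 (0.55 log units; beyond the scatter), giving an estimated value of 7000 nM, between 2000 nM and 25000 nM.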

Compound 4, half-maximal inhibitory concentration: > 25000 nM
Compound 4 was reported as a limit; the forecaster's own chance of this, stated with the estimate: 30%; middle value at least 3.5-fold (0.55 log units) away from the limit.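

The step from compound 1 to compound 4 cannot be read in this assay, because both compounds are reported only as limits, not as numbers: the limit of > 25000 nM in this assay, at which 3 of the 4 values shown sit. The compounds shown leave open whether putting ethoxycarbonyl in place of cyano changes the number at all in the place it occupies in compound 4.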